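A few compounds are considered here, and "the series" means these few. Any claim that something is new, unique, unknown or untested is made for them only; others in the source may bear on it.

Of the compounds shown here, three have been measured so far, all built on the same core. Compound 1 `COc1ccc2c(/C=C/C(=O)c3cc(N)c(OC)c(OC)c3)c[nH]c2c1` carries an amino group together with an additional methoxy group, and in a functional assay on HCT-8 cells (Homo sapiens) for antiproliferative activity, read by MTT assay, with a stated time of 48 h (on this read-out higher numbers stand for weaker inhibition and lower numbers for stronger inhibition), compound 1 gives 368 nM. Compound 2 `COc1cc(C(=O)/C=C/c2c[nH]c3ccccc23)cc([N+](=O)[O-])c1OC` carries a nitro group, and in this assay compound 2 gives 1390 nM. Compound 3 `COc1cc(C(=O)/C=C/c2c[nH]c3ccccc23)cc(SC)c1OC` carries a methylsulfanyl group, and in this assay compound 3 gives 167 nM, the lowest number of the three; the nearest to it is compound 1 and the furthest is compound 2. Among the compounds with values here, the only step between two compounds that differ in a single place is an 8.3-fold lower number from compound 2 to compound 3 (0.92 log units; beyond the scatter).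

Compound 4 `COc1cc(C(=O)/C=C/c2c[nH]c3ccccc23)cc(N)c1OC` differs from compound 3 in one place: amino in place of methylsulfanyl on an aromatic carbon. Within the data shown here, no measured step swaps methylsulfanyl for amino directly, so the nitro-to-methylsulfanyl step is the only direct guide, and it shows that the group at this position can shift the result by a modest amount. Compound 1 also carries an amino group at this position and differs from compound 4 only by one methoxy group, and compound 1 gives 368 nM. Compound 4 is therefore expected to give a somewhat higher number than compound 3, estimated at 320 nM with a range from 130 nM to 800 nM. This estimate corresponds to an expected step of a 1.9-fold higher number from compound 3 to compound 4 (0.28 log units; within the scatter), close to the edge of the scatter.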

Compound 4, half-maximal inhibitory concentration: 577 nM
Compound 4: the middle estimate sits 1.8-fold (0.26 log units) below what was measured; low and high end bracket the measured number.
By their numbers in this assay, from the lowest: compound 3; then compounds 1 and 4 (each within the scatter of the next); then compound 2.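

In this assay this position now carries three different groups on the same core, and amino ranks in the middle: the change is a 3.5-fold higher number from compound 3 to compound 4 (0.54 log units; beyond the scatter) when amino replaces methylsulfanyl, and a 2.4-fold lower number from compound 2 to compound 4 (0.38 log units; beyond the scatter) when amino replaces nitro. Among these three compounds, the numbers therefore rise from methylsulfanyl through amino to nitro, with both steps beyond the usual scatter, so the earlier comparison of nitro and methylsulfanyl now has a third group placed against it. The new pair that differs by a methoxy group gives a 1.6-fold higher number from compound 1 to compound 4 (0.20 log units; within the scatter), a step within the scatter, so with amino at this position, the additional methoxy group of compound 1 makes no readable difference in this one pair.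

No measurement shown here explains why the three groups rank in this order. As far as these compounds go, it also remains open where a slightly larger sulfur group such as ethylsulfanyl or a substituted amine such as dimethylamino would fall, and whether the additional methoxy group would also make no readable difference alongside methylsulfanyl.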